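A methyl-to-nitro swap on a thiosemicarbazide hydroxamate

The compounds below may be only part of what the source reports. "The series", "measured", "known", "first", "only" and "open" are said of these compounds alone.

Measured so far in a functional assay on K562 cells (Homo sapiens) for antiproliferative activity, read by MTT assay; on this read-out lower numbers stand for stronger inhibition and higher numbers for weaker inhibition:
compound 1 `Cc1ccccc1/C(=N/NC(=S)NCCCCCC(=O)NO)c1ccccc1` gives 3510 nM here
compound 2 `Cc1ccc(/C(=N/NC(=S)NCCCCCC(=O)NO)c2ccccc2)cc1` gives 4340 nM here
compound 3 `COc1cccc(/C(C)=N/NC(=S)NCCCCCC(=O)NO)c1` gives 1910 nM here

Compound 2 gives 4340 nM at the high end of these numbers. It stands level with compound 1 within the scatter, while compound 3 shows a lower number. Compound 4 `O=C(CCCCCNC(=S)N/N=C(\c1ccccc1)c1ccc([N+](=O)[O-])cc1)NO` differs from compound 2 by one change nitro in place of methyl on an aromatic carbon with nitro in place of methyl on an aromatic carbon, para to a large group. Going by the values given here, the only measured step nearby is a 1.2-fold higher number from compound 1 to compound 2 (0.09 log units; within the scatter) and it stayed within the scatter. Among the compounds with values here, that step only relocates the methyl, so no measured step tests nitro. No step beyond the scatter is therefore expected in this assay and the estimated step is a 1.2-fold lower number from compound 2 to compound 4 (0.08 log units; within the scatter) in size. For compound 4 the estimated value is 3600 nM with an expected range of 1500 nM to 8000 nM around it.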

Compound 4, half-maximal inhibitory concentration: 2890 nM
Compound 4: the middle estimate sits 1.2-fold (0.10 log units) above what was measured; the range from low to high includes it.
By their numbers in this assay, from the lowest: compounds 3, 4, 1 and 2 (each within the scatter of the next, the first and the last beyond it).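

In this assay, putting nitro in place of methyl on this aromatic carbon, para to a large group, gives a 1.5-fold lower number from compound 2 to compound 4 (0.18 log units; within the scatter), so this first real change of group at the position stays within the scatter, as the earlier shift of the methyl did. Going from 2-methylphenyl to 4-nitrophenyl gives a 1.2-fold lower number from compound 1 to compound 4 (0.08 log units; within the scatter), which also stays within the scatter. Nothing available explains either step.

From the compounds shown here alone, whether an amine or a carboxylic acid on this aromatic carbon would give a step beyond the scatter stays open. So does whether nitro would act the same way on the core of compound 3.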